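Cyano in place of fluoro on compound 3's terminal ring

A few compounds are considered here, and "the series" means these few. Any claim that something is new, unique, unknown or untested is made for them only; others in the source may bear on it.

Among the three compounds measured in an assay on isolated protein for inhibition of tyrosine-protein kinase Mer (Homo sapiens), read by LC-MS (a lower number here means a stronger inhibitor, a higher number a weaker inhibitor), compound 3 `CN(Cc1ccc2nccn2c1)c1nnc(-c2ccc(-c3ccccc3F)cc2)o1` stands lowest, with 15.9 nM. Compound 1 `CN(Cc1ccc2nccn2c1)c1nnc(-c2ccccc2)o1` gives 15800 nM and compound 2 `CN(Cc1ccc2nccn2c1)c1nnc(-c2ccc(C3CC3)cc2)o1` gives 794 nM; the steps of a 990-fold lower number from compound 1 to compound 3 (3.00 log units; beyond the scatter) and a 50-fold lower number from compound 2 to compound 3 (1.70 log units; beyond the scatter) are both large, as is a 20-fold lower number from compound 1 to compound 2 (1.30 log units; beyond the scatter). Compound 4 `CN(Cc1ccc2nccn2c1)c1nnc(-c2ccc(-c3ccccc3C#N)cc2)o1` differs from compound 3 by cyano in place of fluoro on an aromatic carbon. Going by the values given here, no measured step concerns this ring, so none bears directly on the change; the measured steps only show that the 2-fluorophenyl group carries much of the potency. A swap within it is expected to move this assay little, giving a 1.3-fold higher number from compound 3 to compound 4 (0.10 log units; within the scatter). Compound 4 is therefore estimated at 20 nM, within 6 nM to 63 nM.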

Compound 4, half-maximal inhibitory concentration: 25.1 nM
Estimate against measurement, compound 4: 1.3-fold (0.10 log units) below, within the range that was stated.
By their numbers in this assay, from the lowest: compounds 3 and 4 (each within the scatter of the next); then compound 2; then compound 1.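

In this assay the move from fluoro to cyano, ortho to a large group, gives a 1.6-fold higher number from compound 3 to compound 4 (0.20 log units; within the scatter) and so leaves the two groups within the usual scatter of each other. The large gain over hydrogen and cyclopropyl survives this change, with a 630-fold lower number from compound 1 to compound 4 (2.80 log units; beyond the scatter) and a 32-fold lower number from compound 2 to compound 4 (1.50 log units; beyond the scatter) as the steps for 2-cyanophenyl, so it is not tied to fluoro alone. Nothing available explains why the two groups read alike. The compounds shown leave open how a plain phenyl, a methoxy, an amine or a carboxylic acid would read at this place. They also leave open whether cyano would hold elsewhere on that ring.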